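Methoxy for ethyl on the fused ring of compound 3

A few compounds are considered here, and "the series" means these few. Any claim that something is new, unique, unknown or untested is made for them only; others in the source may bear on it.

Of the compounds shown here, three with the shared core have been measured in an assay on CHO-TREX cells for antagonist activity at transient receptor potential cation channel subfamily A member 1 (Homo sapiens), read by FLIPR and calcium flux, with a stated time of 10 min; a lower number here means a stronger inhibitor, a higher number a weaker inhibitor. Compound 1 `CCc1ccccc1-c1ccc2[nH]ncc2c1` gives 584 nM. Compound 2 `Fc1ccc(C(F)(F)F)c(-c2ccc3[nH]ncc3c2)c1` gives 306 nM. Compound 3 `CCc1cc2[nH]ncc2cc1-c1ccccc1C(F)(F)F` gives 50 nM, the lowest of the three numbers; its gaps to compound 2 and to compound 1 both lie beyond the scatter, so compound 3 is the strongest inhibitor of the set so far. Compound 4 `COc1cc2[nH]ncc2cc1-c1ccccc1C(F)(F)F` has not been measured in this assay. It differs from compound 3 by methoxy in place of ethyl on an aromatic carbon. Among the compounds with values here, no measured pair shows this exchange, so the step can only be judged from the structures. A modest loss, not far beyond the scatter, is expected: a 2.4-fold higher number from compound 3 to compound 4 (0.38 log units; beyond the scatter). Compound 4 is therefore estimated at 120 nM, with a range from 40 nM to 400 nM.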

Compound 4, half-maximal inhibitory concentration: 26 nM
The estimate for compound 4 lay 4.6-fold (0.66 log units) above the measured number, and the stated range ends above it.
By their numbers in this assay, from the lowest: compounds 4 and 3 (each within the scatter of the next); then compounds 2 and 1 (each within the scatter of the next).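

In this assay, methoxy in place of ethyl gives a 1.9-fold lower number from compound 3 to compound 4 (0.28 log units; within the scatter), so compound 3 and compound 4 cannot be told apart. This position on the aromatic carbon therefore accepts an oxygen-linked group carrying a hydrogen-bond acceptor without a loss beyond the scatter. No independent evidence bears on this result.

As far as these compounds go, whether ethoxy, a longer chain, an amine or chlorine would hold the number at this position remains open. So does whether the parity between methoxy and ethyl holds with other substituents on the pendant aromatic ring.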